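The source may hold more compounds than are shown below. What is called first, only, known or untested is meant among the compounds shown, and "the series" means these compounds.

The measured compounds:
Compound 1, `C=CCN1C(=O)C(=O)c2cc(-c3ccc(OC)cc3)ccc21`, with 7090 nM in a functional assay on HepG2 cells (Homo sapiens) for antiproliferative activity, read by MTT assay, with a stated time of 48 h; a lower number here means a stronger inhibitor, a higher number a weaker inhibitor.
Compound 2, `COc1ccc(-c2ccc3c(c2)C(=O)C(=O)N3Cc2ccc(F)cc2)cc1`, with 1120 nM in this assay.
Compound 3, `COc1ccc(CN2C(=O)C(=O)c3cc(-c4ccc(OC)c(OC)c4)ccc32)cc1`, with > 10000 nM in this assay, which is a limit and not a number.

Compound 3 therefore gives no number in this assay; it is one of the values sitting at the limit of > 10000 nM in this assay, at which 1 of the 3 values shown sits. Compound 4 is `COc1ccc(CN2C(=O)C(=O)c3cc(-c4ccc5ccccc5c4)ccc32)cc1` and differs from compound 3 in one place: naphthalen-2-yl in place of 3,4-dimethoxyphenyl on an aromatic carbon. Among the compounds with values here, the only measured step, a 6.3-fold lower number from compound 1 to compound 2 (0.80 log units; beyond the scatter), changes the group on the saturated chain carbon bound to the amide-type nitrogen, not the aromatic group that changes here, so it says nothing about this step. Compound 2 and compound 3 differ in two places at once, so their values show only that one of them reaches a number while the other reaches only a limit. Within the data shown here, with no measured step on this aromatic group, the expected step of an at least 2.0-fold lower number from compound 3 to compound 4 (0.30 log units; that floor lies within the scatter) is uncertain in direction. Compound 4 is estimated at 5000 nM, with a range from 1000 nM to 30000 nM.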

Compound 4, half-maximal inhibitory concentration: > 10000 nM
Compound 4: a limit, no number; the forecaster's own chance of this, stated with the estimate: 45%; at least 2.0-fold (0.30 log units) between middle value and limit.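

In this assay compound 4 gives > 10000 nM as a limit and not a number. Compound 3 likewise gives > 10000 nM as a limit. Within the data shown here, with only two limits, no step between compound 3 and compound 4 can be read. The compounds shown leave open whether naphthalen-2-yl and 3,4-dimethoxyphenyl differ at all in their effect on the number.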